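One Stereocentre Changed: What Cytotoxicity to Expect

The source may hold more compounds than are shown below. What is called first, only, known or untested is meant among the compounds shown, and "the series" means these compounds.

Of the compounds shown here, three have been measured in an ADME assay on HFF cells (Homo sapiens) for cytotoxicity, read by neutral red uptake; a lower number here means that less compound is tolerated, a higher number that more compound is tolerated. Compound 1 `Nc1nc2c(ncn2/C=C2\C[C@@H]2[C@H](O)CO)c(=O)[nH]1` sits at the limit of the assay, giving > 300000 nM. Compound 2 `Nc1nc2c(ncn2/C=C2\C[C@H]2[C@@H](O)CO)c(=O)[nH]1` gives 298000 nM in this assay. Compound 3 `Nc1nc2c(ncn2/C=C2/C[C@@H]2[C@H](O)CO)c(=O)[nH]1` also sits at the assay limit, with > 300000 nM. Compound 4 `Nc1nc2c(ncn2/C=C2/C[C@@H]2[C@@H](O)CO)c(=O)[nH]1` has not yet been measured; it differs from compound 3 in configuration only: the two compounds have the same atoms and bonds and differ only in configuration as drawn: 1 of 3 stereo elements differ; a stereocentre at a saturated chain carbon is drawn S in compound 3 and R in compound 4.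

All three measured steps are changes of configuration alone (the fact that compounds 1 and 2 differ only in the configuration as drawn, (the fact that compounds 1 and 3 differ only in the configuration as drawn), (the fact that compounds 2 and 3 differ only in the configuration as drawn)). The step of a number no higher from compound 1 to compound 2 (the limit leaves the size open) and the step of a number no lower from compound 2 to compound 3 (the limit leaves the size open) are left open in size by the limit, and the step that the two limits leave unreadable from compound 1 to compound 3 runs between two limits (the limit of > 300000 nM in this assay, at which 2 of the 3 values shown sit). None of them shows a change beyond the scatter, so a single stereocentre change is not expected to move the read-out either.

Compound 4 is therefore expected to give 300000 nM, with a range from 150000 nM to 600000 nM. The expected step of a number no higher from compound 3 to compound 4 (the limit leaves the size open) is estimated to lie within the scatter, with the assay likely again reporting only its limit.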

Compound 4, half-maximal cytotoxic concentration: > 300000 nM
Compound 4 ended at the assay's limit; the forecaster's own chance of this, stated with the estimate: 80%; the middle value lies on the limit itself.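

Compound 4 in this assay gives > 300000 nM, which is a limit of the assay and not a number. Within the data shown here, this is the first time the saturated chain carbon changes alone. The read-out of compound 4 is again a limit. All that separates the pair is configuration: the fact that compounds 3 and 4 differ only in the configuration as drawn. Among these compounds, the one new step that shows a direction is a number no lower from compound 2 to compound 4 (the limit leaves the size open). The remaining new steps to compound 4 cannot be read in size, so nothing can be said about how large any of them is.

On these data alone, how far the true values of compound 3 and compound 4 lie beyond the limit stays open. Also open, as far as these compounds go, is whether an amine or a longer chain on the shared core would bring the read-out to a measurable number.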